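Swapping the ester tail once more in a calcium channel series

The source may hold more compounds than are shown below. What is called first, only, known or untested is meant among the compounds shown, and "the series" means these compounds.

Of the compounds shown here, two have been measured so far. Compound 1 `C=CCOC(=O)C1=C(C)NC(C)=C(C(=O)OC)C1c1cccc([N+](=O)[O-])c1` carries a vinyl group on a saturated chain carbon bound to an oxygen next to a carbonyl group, and in a functional assay on HEK293 cells for antagonist activity at Voltage-dependent L-type calcium channel subunit alpha-1C (Oryctolagus cuniculus), read by FLIPR (a lower number here means a stronger inhibitor, a higher number a weaker inhibitor), compound 1 gives 15 nM. Compound 2 `COC(=O)C1=C(C)NC(C)=C(C(=O)OCc2cc([N+](=O)[O-])cc([N+](=O)[O-])c2)C1c1cccc([N+](=O)[O-])c1` has a 3,5-dinitrophenyl group at that same place, and in this assay compound 2 gives 55 nM. Compound 2 thus has the higher of the two numbers, and the step of a 3.7-fold higher number from compound 1 to compound 2 (0.56 log units; beyond the scatter) shows that this change weakened inhibition modestly.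

Compound 3 `COC(=O)C1=C(C)NC(C)=C(C(=O)OCCCCc2ccccc2)C1c1cccc([N+](=O)[O-])c1` is the unmeasured compound. 3-phenylpropyl in place of 3,5-dinitrophenyl on a saturated chain carbon bound to an oxygen next to a carbonyl group

Going by the values given here, only the step from compound 1 to compound 2 bears on this change, since it alters the same place; it was a 3.7-fold higher number from compound 1 to compound 2 (0.56 log units; beyond the scatter). Because compound 1 with its small tail gave 15 nM, a tail without nitro groups is expected to bring the number back down somewhat rather than up. The step from compound 2 to compound 3 is therefore estimated as a 2.8-fold lower number from compound 2 to compound 3 (0.44 log units; beyond the scatter).

Compound 3 is expected to give about 20 nM in this assay, with a range from 6 nM to 70 nM.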

Compound 3, half-maximal inhibitory concentration: 10 nM
Compound 3: the middle estimate sits 2.0-fold (0.30 log units) above what was measured, and the stated range covers the measured number.
By their numbers in this assay, from the lowest: compounds 3 and 1 (each within the scatter of the next); then compound 2.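

The step from vinyl to 3-phenylpropyl, a 1.5-fold lower number from compound 1 to compound 3 (0.18 log units; within the scatter), shows that in this assay this position accepts a tail ending in an aromatic ring as well as it accepts the vinyl group, something compound 2 alone could not show. Having a ring in the tail is therefore not what goes with the weaker number of compound 2: 3,5-dinitrophenyl and 3-phenylpropyl each bring one six-membered aromatic ring of carbon only, and yet the change between them gives a 5.5-fold lower number from compound 2 to compound 3 (0.74 log units; beyond the scatter). Nothing available here explains why these tails differ in this way.

This change removes the two nitro groups and lengthens the chain leading to the ring in a single move, so the compounds shown leave open which of the two goes with the step, and a plain benzyl tail would help to separate them. Also open, going by these compounds, is how the number would respond at this position to a tail ending in an amine or a carboxylic acid, or to a chain longer than that of 3-phenylpropyl.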